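The source may report more compounds than this note shows. Statements on the series, on what has been measured and on what is new or still open speak of the compounds shown alone.

Measured so far in an in vitro functional assay on HEK293-A cells for negative allosteric modulation of metabotropic glutamate receptor 5 (Homo sapiens), read by FLIPR and calcium flux; on this read-out higher numbers stand for weaker inhibition and lower numbers for stronger inhibition:

compound 1, `O=C1CC(c2nc(-c3cccc(Cl)c3)no2)CN1c1ccc(Cl)c(Cl)c1`: > 10000 nM
compound 2, `C[C@H](c1ccccc1)N1C[C@H](c2nc(-c3cccc(Cl)c3)no2)CC1=O`: 1600 nM

Compound 1 carries a 3,4-dichlorophenyl on the amide-type nitrogen of its five-membered ring. In this assay compound 1 gives only a limit, > 10000 nM, so no number is known for it; the evidence for compound 1 is thus just (the limit of > 10000 nM in this assay, at which 1 of the 2 values shown sits). Compound 2 carries a different group on that nitrogen and differs from compound 1 in several places. In this assay compound 2 gives 1600 nM. For the measured compounds named here, no step between these two can be sized, since compound 1 has no number.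

Compound 3, `O=C1CC(c2nc(-c3cccc(Cl)c3)no2)CN1c1ccccc1Cl`, is not yet measured. It differs from compound 1 in one place: 2-chlorophenyl in place of 3,4-dichlorophenyl on an amide-type nitrogen in a ring. Going by the values given here, with compound 1 sitting only at a limit, the direction of the change cannot be read from a measured pair; the one number on hand, that of compound 2, shows that an aryl-free group on this nitrogen can give a measurable value. Compound 3 is therefore expected to land near 8000 nM, in the range 2000 nM to 30000 nM, which would mean an estimated step of an at least 1.2-fold lower number from compound 1 to compound 3 (0.09 log units; that floor lies within the scatter) in this assay.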

Compound 3, half-maximal inhibitory concentration: 680 nM
Beside the measured number, compound 3's estimate is 12-fold (1.07 log units) above it; measured number below the stated range.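

Compound 1 alone could not show whether an aryl group directly on this amide-type nitrogen is compatible with a measurable value in this assay, and compound 2 differs from it in several places. Within the shared core, the aryl group can stay on that nitrogen, and replacing 3,4-dichlorophenyl with 2-chlorophenyl gives an at least 14-fold lower number from compound 1 to compound 3 (1.16 log units; beyond the scatter), so the chlorine pattern on this ring matters greatly for this pair. For compound 1, the printed > 10000 nM is a limit of the assay and not a number, so the true size of the step remains unknown and only its lower bound can be read: the limit of > 10000 nM in this assay, at which 1 of the 3 values shown sits.

This single change both removes a chlorine and alters the pattern of chlorine on the ring, so the compounds shown cannot separate those two effects, and an unsubstituted phenyl would help to do so. They also leave open whether the chlorine of compound 3 can be exchanged for another small group, as in 2-fluorophenyl or 2-methylphenyl, while keeping a measurable value.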